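This account rests on a few compounds, and the source may have more. Where it says the series, first, only, none or still open, it means among the compounds named here.

Working notes on the series. Compound 1 `COc1ccc(Nc2cc(C3CCCCC3)oc(=O)c2)cc1` carries a cyclohexyl on the shared core. In a functional assay on KB cells (Homo sapiens) for cytotoxicity, read by MTT assay, with a stated time of 72 h (a lower number here means that less compound is needed, a higher number that more compound is needed for the effect), compound 1 gives 8.32 uM. Compound 2 `COc1ccc(Nc2cc(C(C)C)oc(=O)c2)cc1` carries an isopropyl in that place. In this assay compound 2 gives only a limit of the assay, > 30 uM. The step of an at least 3.6-fold higher number from compound 1 to compound 2 (0.55 log units; beyond the scatter) is therefore known only as a lower bound, because compound 2 sits at the limit of > 30 uM in this assay, at which 1 of the 2 values shown sits. Compound 2 thus stands at the weaker end of the two values shown, without a number of its own.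

Compound 3 `COc1ccc(Nc2cc(C3CCCC3)oc(=O)c2)cc1` is not yet measured. It differs from compound 2 by cyclopentyl in place of isopropyl on an aromatic carbon. Within the data shown here, the one measured step that bears on this change is the one from cyclohexyl to isopropyl, which was at least modest and went toward a higher number when the ring was removed. A partial return toward the value of compound 1 is expected with the cyclopentyl, though the size is uncertain since compound 2 is a limit. For compound 3 the expected step in this assay is an at least 2.0-fold lower number from compound 2 to compound 3 (0.30 log units; that floor lies within the scatter). Compound 3 is estimated at 15 uM in this assay, with a range from 6 uM to 40 uM.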

Compound 3, concentration for half-maximal effect: 8.38 uM
Beside the measured number, compound 3's estimate is 1.8-fold (0.25 log units) above it, and the stated range covers the measured number.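

The cyclopentyl on this aromatic carbon, next to the ring oxygen, brings back what the isopropyl lost in this assay, and the step of an at least 3.5-fold lower number from compound 2 to compound 3 (0.55 log units; beyond the scatter) is only a lower bound because compound 2 stands at a limit: the limit of > 30 uM in this assay, at which 1 of the 3 values shown sits. The step of a 1.0-fold higher number from compound 1 to compound 3 (0.00 log units; within the scatter) adds what the first pair could not show: the one five-membered non-aromatic ring and the cyclohexyl cannot be told apart here, so the change of ring carries no readable effect at this place. Among these three compounds, the two with a ring therefore stay together and the isopropyl compound alone stands apart, with no compound shown going against that pattern.

The isopropyl differs from both ring groups in its carbon count as well as in having no ring, so the compounds shown do not say which of the two differences matters; an open pentyl chain would separate them. Also open, on these data alone, is how far this place tolerates other groups, such as a phenyl, a cyclopropyl or a ring holding an amine, as in piperidinyl.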